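The source may hold more compounds than are shown below. What is called first, only, known or untested is meant among the compounds shown, and "the series" means these compounds.

In a functional assay on RAW264.7 cells (Mus musculus) for inhibition, read by ELISA, with a stated time of 24 h (a lower number here means that less compound is needed, a higher number that more compound is needed for the effect), the measured values are
Compound 1 `CC/C=C\C[C@H]1C(=O)C=C[C@H]1CC(=O)OCC` gives 20000 nM
Compound 2 `CC/C=C\C[C@H]1C(=O)C=C[C@H]1CC(=O)OCCC` gives 23000 nM
Compound 3 `CC/C=C\C[C@H]1C(=O)C=C[C@H]1CC(=O)Oc1ccc(O)cc1` gives 23000 nM

Compound 3 stands level with compound 2 and within the scatter of compound 1. The change to compound 4 `CC/C=C\C[C@H]1C(=O)C=C[C@H]1CC(=O)OCCOCCO` is 2-(2-hydroxyethoxy)ethyl in place of 4-hydroxyphenyl on an oxygen next to a carbonyl group with 2-(2-hydroxyethoxy)ethyl in place of 4-hydroxyphenyl on an oxygen next to a carbonyl group. Three measured steps alter the group on that oxygen, namely a 1.2-fold higher number from compound 1 to compound 2 (0.06 log units; within the scatter) and a 1.2-fold higher number from compound 1 to compound 3 (0.06 log units; within the scatter) and no change at the digits printed from compound 2 to compound 3 (within the scatter) and all of them stay within the scatter. Within the data shown here, none of the measured compounds carries the entering group, so the range is kept wide. No step beyond the scatter is expected in this assay here. The expected change is a 1.0-fold lower number from compound 3 to compound 4 (0.02 log units; within the scatter) and so lies within the scatter. Compound 4 is estimated at 22000 nM with an expected range from 11000 nM to 45000 nM in that assay.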

Compound 4, half-maximal effective concentration: 36000 nM
The estimate for compound 4 lay 1.6-fold (0.21 log units) below the measured number; the range from low to high includes it.
By their numbers in this assay, from the lowest: compounds 1, 2, 3 and 4 (each within the scatter of the next).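

In this assay, the group on the oxygen next to a carbonyl group can also be 2-(2-hydroxyethoxy)ethyl, with a 1.6-fold higher number from compound 3 to compound 4 (0.19 log units; within the scatter), a 1.6-fold higher number from compound 2 to compound 4 (0.19 log units; within the scatter) and a 1.8-fold higher number from compound 1 to compound 4 (0.26 log units; within the scatter). This group, which has no ring, thus stays within the scatter of all three earlier compounds, and the four compounds cannot be told apart by this assay. No supporting data bear on this result.

From the compounds shown here alone, whether an amine, a carboxylic acid or a much longer chain in this place would give a step beyond the scatter remains open. Any change to the shared core also remains open.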